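The compounds below may be only part of what the source reports. "The series", "measured", "known", "first", "only" and "open" are said of these compounds alone.

Compound 2 `CCN(CC)CCCOc1ccc(-c2nc3ccc(Oc4ccc(C(C)(C)C)cc4)cc3o2)cc1` is reported as "not active" (no number reported) in an assay on isolated protein for inhibition of advanced glycosylation end product-specific receptor (Homo sapiens), read by FRET, with stated times of 30 min and 1 h, tested at 4 uM (a higher number here means more inhibition at the concentration tested (going by the name of the read-out), a lower number less inhibition), so no single number stands for it. Compound 1 `N[C@@H]1CCN(CCCOc2ccc(-c3nc4ccc(Oc5ccc(Cl)cc5)cc4o3)cc2)C1` carries the amine that compound 3 will carry. In this assay compound 1 gives 19.6%. Compound 3 `CC(C)(C)c1ccc(Oc2ccc3nc(-c4ccc(OCCCN5CC[C@@H](N)C5)cc4)oc3c2)cc1` arises from compound 2 through the change (3-aminopyrrolidin-1-yl in place of diethylamino on a saturated chain carbon, three bonds along the chain from an oxygen on an aromatic ring). Because compound 1 gives 19.6% in this assay, the step from compound 2 to compound 3 is expected to raise the read-out in this assay by an amount beyond the usual scatter. Compound 3 is therefore estimated at 15% in this assay, with a range from 0% to 35%.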

Compound 3, a percentage reported as inhibition, at one concentration (the size of the read-out at that concentration, not a potency): "not active" (no number reported)
For compound 3 the study gives words and no number; there is nothing to compare the estimate with.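

Among these compounds, compound 2 and compound 3 are both reported in words alone in this assay, so no step between them can be read. Nothing shown bears on this result. The compounds shown leave open whether exchanging diethylamino for 3-aminopyrrolidin-1-yl changes inhibition at all.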